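A few compounds are considered here, and "the series" means these few. Any claim that something is new, unique, unknown or untested is made for them only; others in the source may bear on it.

Of the compounds shown here, three have been measured so far in an assay on isolated protein for inhibition of Dihydrofolate reductase (Homo sapiens), read by spectrophotometry, using NADPH, with stated times of 5 s and 6 min, tested at 5 uM; on this read-out higher numbers stand for a stronger effect at the one concentration tested and lower numbers for a weaker effect.

Compound 1 `COc1ccc(OCCCON2C(N)=NC(N)=NC23CCOCC3)cc1` sits at the assay's limit, > 90%.
Compound 2 `NC1=NC2(CCOCC2)N(OCCCOc2cccc(Cl)c2Cl)C(N)=N1` gives 81.7%.
Compound 3 `NC1=NC2(CCOCC2)N(OCCCOc2ccc(F)cc2)C(N)=N1` also sits at the assay's limit, > 90%.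

Compound 3 therefore stands at the limit of > 90% in this assay, at which 2 of the 3 values shown sit, so only a limit is known for it, not a number. Compound 4 `CC(C)(C)c1ccc(OCCCON2C(N)=NC(N)=NC23CCOCC3)cc1` is not yet measured and differs from compound 3 in one place: tert-butyl in place of fluoro on an aromatic carbon. Going by the values given here, no measured step swaps exactly these two groups. The nearest is a step that the two limits leave unreadable from compound 1 to compound 3, while the two steps through compound 2, a number at least 8.3 percentage points lower from compound 1 to compound 2 (that floor lies within the scatter) and a number at least 8.3 percentage points higher from compound 2 to compound 3 (that floor lies within the scatter), have floors inside the scatter. All three measured compounds stay near or at the limit, so no step beyond the scatter is expected here: a number no higher from compound 3 to compound 4 (the limit leaves the size open). Compound 4 is thus estimated at 90%, between 72% and 98%, and may again be reported only as a limit.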

Compound 4, a percentage reported as inhibition, at one concentration (the size of the read-out at that concentration, not a potency): > 90%
Compound 4: only a limit was reported (the forecaster's own chance of this, stated with the estimate: 55%); the middle value sits exactly at the limit.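

Compound 1, compound 3 and compound 4 each carry only a limit, not a number, so no step between them can be read: the limit of > 90% in this assay, at which 3 of the 4 values shown sit.

The compounds shown leave open whether methoxy, fluoro and tert-butyl differ at all in their effect.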